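The compounds below may be only part of what the source reports. "The series", "measured", "known", "first", "only" and "open" are said of these compounds alone.

In a functional assay on MDA-MB-231 cells (Homo sapiens) for antiproliferative activity, with a stated time of 72 h (a lower number here means that less compound is needed, a higher number that more compound is needed for the effect), compound 1 (`O=C(O)c1ccc(N(Cc2ccc(C3CCCCC3)cc2)C(=O)[C@H]2CCN2S(=O)(=O)c2c(F)c(F)c(F)c(F)c2F)c(F)c1`) reads > 10000 nM as a limit of the assay and not a number. Among the compounds with values here, compound 2 (`COC(=O)c1ccc(N(Cc2ccc(C3CCCCC3)nc2)C(=O)[C@H]2CCN2S(=O)(=O)c2c(F)c(F)c(F)c(F)c2F)cc1O`) gives 2000 nM as the only actual number so far. Compound 3 (`COC(=O)c1ccc(N(Cc2cnc(C3CCCCC3)cn2)C(=O)[C@H]2CCN2S(=O)(=O)c2c(F)c(F)c(F)c(F)c2F)cc1O`) carries 5-cyclohexylpyrazin-2-yl in place of 6-cyclohexylpyridin-3-yl on a saturated chain carbon bound to an amide-type nitrogen. Starting from compound 2 at 2000 nM and with no measured step bearing on this change, no shift beyond the usual scatter is expected in this assay here. The expected step of a 1.5-fold higher number from compound 2 to compound 3 (0.18 log units; within the scatter) is therefore small. For compound 3 the estimated value is 3000 nM with 1000 nM to 10000 nM as the expected range.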

Compound 3, half-maximal effective concentration: 1600 nM
The estimate for compound 3 lay 1.9-fold (0.27 log units) above the measured number; low and high end bracket the measured number.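

Swapping 6-cyclohexylpyridin-3-yl for 5-cyclohexylpyrazin-2-yl on a saturated chain carbon bound to an amide-type nitrogen gives a 1.3-fold lower number from compound 2 to compound 3 (0.10 log units; within the scatter) in this assay and is the first step that can be read at this position. It shows that the aromatic ring here can hold a second ring nitrogen without the number moving beyond the scatter. Within the data shown here, nothing measured so far bears on why the two compounds read alike. The compounds shown leave open how the number would respond to a more distinct change at this position, such as an amine on the cyclohexyl ring or a longer chain in its place.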